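The source may hold more compounds than are shown below. What is called first, only, known or untested is meant among the compounds shown, and "the series" means these compounds.

Of the compounds shown here, three sharing one core have been measured in a functional assay on the whole organism for inhibition, with Lemna aequinoctialis as the target, tested at 1000 ug/mL; a higher number here means more inhibition of growth at the concentration tested, a lower number less inhibition of growth. Compound 1 `C=CCNC(=S)N/N=C1\C(=O)Nc2ccc([N+](=O)[O-])cc21`, with allyl on an amide-type nitrogen, gives 50%. With 3-methylphenyl in that place, compound 2 `Cc1cccc(NC(=S)N/N=C2\C(=O)Nc3ccc([N+](=O)[O-])cc32)c1` gives 25%, and with 4-iodophenyl, compound 3 `O=C1Nc2ccc([N+](=O)[O-])cc2/C1=N/NC(=S)Nc1ccc(I)cc1` gives 25%. Compound 2 therefore stands level with compound 3, as the step of no change at the digits printed from compound 2 to compound 3 (within the scatter) shows, while compound 1 stands higher than both: a number 25 percentage points lower from compound 1 to compound 2 (beyond the scatter) and a number 25 percentage points lower from compound 1 to compound 3 (beyond the scatter).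

Compound 4 `N#Cc1cccc(NC(=S)N/N=C2\C(=O)Nc3ccc([N+](=O)[O-])cc32)c1` differs from compound 2 at one place: cyano in place of methyl on an aromatic carbon. In words, this is cyano in place of methyl on an aromatic carbon, turning 3-methylphenyl into 3-cyanophenyl. Among the measured compounds shown here, no measured step makes this exact change. The closest evidence is the exchange of one substituted phenyl for another in no change at the digits printed from compound 2 to compound 3 (within the scatter). The larger steps both replace allyl with a substituted phenyl, a different kind of change. No step beyond the scatter is therefore expected, and the estimated step is small: a number 5 percentage points higher from compound 2 to compound 4 (within the scatter). In this assay, the estimate for compound 4 is 30%, with an expected range from 15% to 50%.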

Compound 4, percent growth inhibition at one concentration: 25%
The estimate for compound 4 lay 5 percentage points above the measured number; measured number inside the range.
By their numbers in this assay, from the lowest: compounds 2, 3 and 4 (each within the scatter of the next); then compound 1.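

In this assay, exchanging methyl for cyano on an aromatic carbon of the phenyl ring gives a flat result (no change at the digits printed from compound 2 to compound 4 (within the scatter)), so this small edit, meta to a large group, shows no effect at the concentration tested. Compound 4 also matches the 4-iodophenyl analogue (no change at the digits printed from compound 3 to compound 4 (within the scatter)) and keeps the gap from the allyl compound (a number 25 percentage points lower from compound 1 to compound 4 (beyond the scatter)), so all three substituted phenyl compounds now sit apart from compound 1 but not from one another. No supporting measurement is available to explain this flat result.

Going by these compounds, it remains open whether an amine or a carboxylic acid on that same ring carbon would shift the number. It is also unknown whether a longer chain in place of allyl on the amide-type nitrogen would keep the higher reading of compound 1.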